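Chain-end amine swap on a quinoline ether amide

The compounds below may be only part of what the source reports. "The series", "measured", "known", "first", "only" and "open" are said of these compounds alone.

Three measured compounds share one core and differ only in the aryl group on the triazole nitrogen. Compound 1 `COc1cc2c(Oc3ccc(NC(=O)c4nnn(-c5ccc(F)cc5)c4C(F)(F)F)cc3F)ccnc2cc1OCCCN1CCCC1` gives 80 nM in a functional assay on A549 cells (Homo sapiens) for cytotoxicity, read by MTT assay, with a stated time of 72 h; a higher number here means a weaker inhibitor, a lower number a stronger inhibitor. Compound 2 `COc1cc2c(Oc3ccc(NC(=O)c4nnn(-c5ccc(C)cc5)c4C(F)(F)F)cc3F)ccnc2cc1OCCCN1CCCC1` gives 370 nM in this assay, and compound 3 `COc1cc2c(Oc3ccc(NC(=O)c4nnn(-c5ccccc5C(F)(F)F)c4C(F)(F)F)cc3F)ccnc2cc1OCCCN1CCCC1` gives 200 nM in this assay. The steps among them are a 4.6-fold higher number from compound 1 to compound 2 (0.67 log units; beyond the scatter), a 2.5-fold higher number from compound 1 to compound 3 (0.40 log units; beyond the scatter) and a 1.9-fold lower number from compound 2 to compound 3 (0.27 log units; within the scatter). Compound 3 thus holds the second highest of the three numbers, close to compound 2 and further from compound 1.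

Compound 4 `COc1cc2c(Oc3ccc(NC(=O)c4nnn(-c5ccccc5C(F)(F)F)c4C(F)(F)F)cc3F)ccnc2cc1OCCCN1CCC(C)CC1` keeps the whole of compound 3 apart from the amine at the end of the propoxy chain: 4-methylpiperidin-1-yl in place of pyrrolidin-1-yl on a saturated chain carbon, three bonds along the chain from an oxygen on an aromatic ring. For the measured compounds named here, none of the three measured steps touches this part of the molecule; all of them concern the aryl group on the triazole nitrogen, so no measured step bears directly on the change from compound 3 to compound 4. With nothing pointing either way, the expected step of no change at the digits printed from compound 3 to compound 4 (within the scatter) in this assay is none beyond the scatter. Compound 4 is therefore expected to give about 200 nM, within a range of 80 nM to 500 nM, because compound 3 gives 200 nM.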

Compound 4, half-maximal inhibitory concentration: 220 nM
Compound 4: middle estimate off by 1.1-fold (0.04 log units), on the low side; low and high end bracket the measured number.
By their numbers in this assay, from the lowest: compound 1; then compounds 3, 4 and 2 (each within the scatter of the next).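

The change at the end of the propoxy chain moves the comparison away from the aryl group on the triazole nitrogen, and in this assay it gives a 1.1-fold higher number from compound 3 to compound 4 (0.04 log units; within the scatter). With the 2-(trifluoromethyl)phenyl group held fixed, the six-membered 4-methylpiperidin-1-yl ring therefore reads the same as the five-membered pyrrolidin-1-yl ring at this position, although it carries more heavy atoms, whereas a change in the aryl group alone gives a 4.6-fold higher number from compound 1 to compound 2 (0.67 log units; beyond the scatter). Nothing measured here accounts for this lack of a step.

The compounds shown leave open whether the same swap would also leave the number in place on the 4-fluorophenyl group of compound 1, which gives 80 nM. They also leave open how this position would respond to a morpholine ring, a 4-methylpiperazine ring, an open-chain dimethylamino group or a primary amine, and whether a shorter or longer chain would read differently from the propoxy chain.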